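Restoring an aryl group at the ring amine

The compounds below may be only part of what the source reports. "The series", "measured", "known", "first", "only" and "open" are said of these compounds alone.

Of the compounds shown here, three sharing one core have been tested in a functional assay on the whole organism for antagonist activity, with Mus musculus as the target; a higher number here means that more compound is needed for the effect, a lower number that less compound is needed. Compound 1 `COc1cc(N)c(Cl)cc1NC(=O)C1CCN(Cc2cccc(C)c2)CC1` gives 2.4 mg/kg. Compound 2 `COc1ccc(CN2CCC(C(=O)Nc3cc(Cl)c(N)cc3OC)CC2)cc1` gives 0.9 mg/kg. Compound 3 `CCN1CCC(C(=O)Nc2cc(Cl)c(N)cc2OC)CC1` gives only a limit of the assay, > 10 mg/kg, so no number is known for it. Compound 3 thus stands at the limit of > 10 mg/kg in this assay, at which 1 of the 3 values shown sits. The step of an at least 4.1-fold higher number from compound 1 to compound 3 (0.61 log units; beyond the scatter) and the step of an at least 11-fold higher number from compound 2 to compound 3 (1.04 log units; beyond the scatter) both show that putting methyl in place of an aryl group on the saturated chain carbon bound to the ring amine nitrogen raises the number well beyond the scatter. Compound 4 `COc1cc(N)c(Cl)cc1NC(=O)C1CCN(Cc2ccc(O)cc2)CC1` goes the other way: 4-hydroxyphenyl in place of methyl on a saturated chain carbon bound to an amine nitrogen in a ring. Because the step of an at least 11-fold higher number from compound 2 to compound 3 (1.04 log units; beyond the scatter) was large, and the 4-hydroxyphenyl group of compound 4 differs from the 4-methoxyphenyl group of compound 2 only by one methyl, a large fall in this assay is expected, an at least 6.6-fold lower number from compound 3 to compound 4 (0.82 log units; beyond the scatter). Compound 4 is estimated at 1.5 mg/kg, with a range from 0.5 mg/kg to 5 mg/kg.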

Compound 4, dose for half-maximal effect: > 8 mg/kg
Compound 4 was reported as a limit (the forecaster's own chance of this, stated with the estimate: 5%); middle value at least 5.3-fold (0.72 log units) away from the limit.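

In this assay, an aryl group at this place does not by itself keep the number low: hydrogen in place of methyl on the oxygen of the aromatic ring gives an at least 8.8-fold higher number from compound 2 to compound 4 (0.94 log units; beyond the scatter), so this one small change on the ring separates two aryl compounds. The 4-hydroxyphenyl group also compares poorly with 3-methylphenyl, with an at least 3.3-fold higher number from compound 1 to compound 4 (0.52 log units; beyond the scatter), so among the three aryl groups shown, only compound 4 fails to give a number well under the limits seen here. On these data alone, compound 3 and compound 4 are both reported only as limits, so the step between them cannot be read, and it remains unknown whether 4-hydroxyphenyl improves on methyl at all.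

As far as these compounds go, the actual number for compound 4 remains open. So does the question of whether a 4-ethoxyphenyl or a 4-aminophenyl group at this place would behave like 4-methoxyphenyl or like 4-hydroxyphenyl.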